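Ethyl for chloro on the aryl group: compound 4

The source may report more compounds than this note shows. Statements on the series, on what has been measured and on what is new or still open speak of the compounds shown alone.

Measured so far in an assay on HEK-293T cells for displacement of a labelled ligand from corticotropin-releasing factor receptor 1 (Homo sapiens), read by scintillation counting, with a stated time of 2 h; a lower number here means a stronger inhibitor, a higher number a weaker inhibitor:
compound 1 `CCN(C)c1cc(C)nc2c1NC(=O)CN2c1ccc(C(C)C)cc1Br`: 16.4 nM
compound 2 `CCCCN(CC)c1cc(C)nc2c1NC(=O)CN2c1ccc(Br)cc1Cl`: 2.7 nM
compound 3 `CCN(C)c1cc(C)nc2c1N(CCCCF)C(=O)CN2c1ccc(C(C)C)cc1Br`: 13.9 nM

Compound 2 gives the lowest number of the three in this assay; its nearest neighbour is compound 3 and its furthest is compound 1, and both gaps lie beyond the scatter. Compound 2 differs from compounds 1 and 3 in several places at once, so only the values themselves can be compared, not any single change. Going by the values given here, the one single-point step measured, a 1.2-fold lower number from compound 1 to compound 3 (0.07 log units; within the scatter), concerns a substituent on the amide-type nitrogen in a ring and lies within the scatter; it says nothing about the aryl group.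

Compound 4 `CCCCN(CC)c1cc(C)nc2c1NC(=O)CN2c1ccc(Br)cc1CC` is the next compound. Its change from compound 2 is ethyl in place of chloro on an aromatic carbon. Among the compounds with values here, no measured step touches the aryl substituents, so no step bears on this one. With nothing to lean on, the number for compound 4 in this assay is expected to stay near that of compound 2, and the step of a 1.5-fold higher number from compound 2 to compound 4 (0.17 log units; within the scatter) is estimated to fall within the scatter. Compound 4 is therefore estimated at 4 nM, with a range of 1.5 nM to 12 nM.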

Compound 4, inhibition constant: 2.5 nM
Estimate against measurement, compound 4: 1.6-fold (0.20 log units) above, within the range that was stated.
By their numbers in this assay, from the lowest: compounds 4 and 2 (each within the scatter of the next); then compounds 3 and 1 (each within the scatter of the next).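

In this assay, going by these compounds alone, the change from 4-bromo-2-chlorophenyl to 4-bromo-2-ethylphenyl gives a 1.1-fold lower number from compound 2 to compound 4 (0.03 log units; within the scatter), which is the first single-point reading on the aryl group; the earlier step concerned only the amide-type nitrogen. On this aromatic carbon, ortho to a large group, ethyl with 2 heavy atoms and chloro with 1 heavy atom cannot be told apart in this matched pair, so chloro is not needed here to keep the number within the scatter of that of compound 2. No measurement shown gives a reason for this result.

From the compounds shown here alone, it remains open how far this position accepts other groups, such as methoxy, trifluoromethyl or a longer chain such as n-propyl, and whether any of them would move the number beyond the scatter. Also open, going by these compounds, is whether the equivalence of ethyl and chloro holds with the ethyl(methyl)amino group of compound 1 in place of the butyl(ethyl)amino group shared by compound 2 and compound 4.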